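Cyclobutylmethoxy replacing the azetidine on the shared core

The source may hold more compounds than are shown below. What is called first, only, known or untested is meant among the compounds shown, and "the series" means these compounds.

Compound 3 `CC1(CS(C)(=O)=O)CN(c2cc(COc3ccc(F)c(F)c3F)nc(-c3ccccn3)n2)C1` gives 6310 nM in a functional assay on cells for antagonist activity at Free fatty acid receptor 1 (Homo sapiens), read by TR-FRET and inositol phosphate accumulation, with a stated time of 2 h; on this read-out higher numbers stand for weaker inhibition and lower numbers for stronger inhibition. On the numbers seen so far it stands second highest of three: compound 1 `Cc1cc(COc2ccc(C#N)cc2)nc(-c2ccccn2)n1` gives 31600 nM in this assay, and compound 2 `CC1(C)CN(c2cc(COc3ccc(F)c(F)c3F)nc(-c3ccccn3)n2)C1` gives 25.1 nM in this assay. Among the compounds with values here, the one single-point step measured, a 250-fold higher number from compound 2 to compound 3 (2.40 log units; beyond the scatter), is large and shows that this position of the shared core is sensitive to what is attached there.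

Compound 4 `Fc1ccc(OCc2cc(OCC3CCC3)nc(-c3ccccn3)n2)c(F)c1F` differs from compound 3 by cyclobutylmethoxy in place of 3-methyl-3-((methylsulfonyl)methyl)azetidin-1-yl on an aromatic carbon. Within the data shown here, no measured step covers this exchange: the only step at this position is the methylsulfonyl addition, and nothing in the set shows an ether group or an all-carbon ring attached through oxygen. Compound 2, which carries a four-membered ring without the methylsulfonyl, gives the lowest number in this assay, and compound 3 with the methylsulfonyl gives a much higher one; compound 4 carries a four-membered ring and no methylsulfonyl, but is joined through oxygen rather than nitrogen. On this ground a step toward a lower number, a 25-fold lower number from compound 3 to compound 4 (1.40 log units; beyond the scatter), is expected for compound 4, with wide uncertainty. Compound 4 is estimated to give 250 nM in this assay, with a range from 30 nM to 3000 nM.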

Compound 4, half-maximal inhibitory concentration: 12.6 nM
Estimate against measurement, compound 4: 20-fold (1.30 log units) above; the whole stated range lies above it.
By their numbers in this assay, from the lowest: compounds 4 and 2 (each within the scatter of the next); then compound 3; then compound 1.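

Exchanging the 3-methyl-3-((methylsulfonyl)methyl)azetidin-1-yl group of compound 3 for cyclobutylmethoxy on this aromatic carbon of the shared core gives a 500-fold lower number from compound 3 to compound 4 (2.70 log units; beyond the scatter) in this assay, so the high number of compound 3 is not a general feature of substitution at this position. The comparison with the unsubstituted azetidine, a 2.0-fold lower number from compound 2 to compound 4 (0.30 log units; within the scatter), shows that 3,3-dimethylazetidin-1-yl and cyclobutylmethoxy cannot be told apart here, so in this pair the ring nitrogen attached to the aromatic carbon is not needed for a low number, and an ether attachment serves equally well. No measurement on hand bears on why these groups give such different numbers at this position.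

Still open, going by these compounds, is whether a methylsulfonyl group placed on the cyclobutyl ring of cyclobutylmethoxy would raise the number as sharply as it does on the azetidine, which would separate the effect of that group from the kind of ring carrying it. Also open, on these data alone, is how this position responds to an open chain such as butoxy, to a primary amine or a carboxylic acid on the four-membered ring, or to a larger all-carbon ring such as cyclohexylmethoxy.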